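A few compounds are considered here, and "the series" means these few. Any claim that something is new, unique, unknown or untested is made for them only; others in the source may bear on it.

Measured compounds:
compound 1, `Cc1cc(C)nc(NS(=O)(=O)c2ccc(NCc3coc4ccccc4c3=O)cc2)n1` — 93600 nM
compound 2, `CCOC1Oc2ccccc2C(=O)/C1=C/Nc1ccc(S(=O)(=O)Nc2cc(C)on2)cc1` — 25800 nM

In a functional assay on MCF7 cells (Homo sapiens) for cytotoxicity, read by sulforhodamine B assay, with a stated time of 72 h (a higher number here means a weaker inhibitor, a lower number a stronger inhibitor), compound 1 gives 93600 nM, the higher of the two numbers recorded so far. Compound 2, built on a different core, gives 25800 nM in this assay, and the gap between the two values lies beyond the usual scatter of this kind of measurement, so compound 1 is the weaker of the two. Among the measured compounds shown here, no pair of measured compounds differs in a single place, so there is no measured step to lean on.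

Compound 3, `O=c1c(CNc2ccc(S(=O)(=O)Nc3ccccn3)cc2)coc2ccccc12`, is yet to be measured. It differs from compound 1 at one place: pyridin-2-yl in place of 4,6-dimethylpyrimidin-2-yl on a sulfonamide nitrogen. For the measured compounds named here, with only two unrelated values available, the size and direction of this change cannot be anchored to any measured step. The expectation is a step of a 1.2-fold lower number from compound 1 to compound 3 (0.10 log units; within the scatter) from compound 1, which amounts to no change beyond the scatter. Compound 3 is therefore estimated to give 75000 nM in this assay, with a range from 20000 nM to 250000 nM.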

Compound 3, half-maximal inhibitory concentration: > 100000 nM
Compound 3: only a limit was reported; the forecaster's own chance of this, stated with the estimate: 20%; at least 1.3-fold (0.12 log units) between middle value and limit.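

Among the compounds shown here, compound 3 provides the first measured step at this place, on a sulfonamide nitrogen, and its reading of > 100000 nM in this assay is a limit of the assay and not a number. The step reads an at least 1.0-fold higher number from compound 1 to compound 3 (0.02 log units; that floor lies within the scatter), so pyridin-2-yl in place of 4,6-dimethylpyrimidin-2-yl brings no gain on the core of compound 1, although the floor of this step does not separate the two compounds. How far compound 3 really lies from compound 1 cannot be told, because its reading rests at the limit: the limit of > 100000 nM in this assay, at which 1 of the 3 values shown sits.

What a plain pyrimidin-2-yl would give on the same sulfonamide nitrogen stays open, so the compounds shown do not separate the part played by the methyl groups from that of the extra ring nitrogen. Also open, from the compounds shown here alone, is whether a group of another kind at this place, such as a phenyl ring or a carboxylic acid, would move the value in this assay at all.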